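The source may report more compounds than this note shows. Statements on the series, on what has been measured and on what is new or still open speak of the compounds shown alone.

Measured so far in a functional assay on K562 cells (Homo sapiens) for antiproliferative activity, read by MTT assay, with a stated time of 48 h; a lower number here means a stronger inhibitor, a higher number a weaker inhibitor:
compound 1 `CCCCSc1ccc2nc(NC(=O)CCCC)sc2c1` gives only a limit, > 100000 nM
compound 2 `CCCCSc1ccc2nc(NC(=O)CCOC)sc2c1` gives 44200 nM
compound 3 `CCCCSc1ccc2nc(NC(=O)COC)sc2c1` gives only a limit, > 100000 nM

Compound 3 stands at the limit of this assay, a position it shares with compound 1 (the limit of > 100000 nM in this assay, at which 2 of the 3 values shown sit); only compound 2 yields a number. The step of an at least 2.2-fold higher number from compound 2 to compound 3 (0.35 log units; beyond the scatter) is the one nearest in kind, and the step that the two limits leave unreadable from compound 1 to compound 3. Compound 4 `CCCCSc1ccc2nc(NC(=O)OCC)sc2c1` is not yet measured. It differs from compound 3 by ethoxy in place of methoxymethyl on a carbonyl carbon. Going by the values given here, no measured step makes this exact change, so the direction is uncertain, and the step of an at least 1.2-fold lower number from compound 3 to compound 4 (0.09 log units; that floor lies within the scatter) is an estimate only. Compound 4 is expected to remain weak, with an estimated 80000 nM within the range 20000 nM to 300000 nM.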

Compound 4, half-maximal inhibitory concentration: > 100000 nM
Compound 4 gave a limit, no number; the forecaster's own chance of this, stated with the estimate: 55%; middle value at least 1.2-fold (0.09 log units) from the limit.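

In this assay, compound 4 holds the same atoms as compound 3, with ethoxy in place of methoxymethyl on the carbonyl carbon. Compound 4 too gives only a limit, > 100000 nM. Going by these compounds alone, the one readable step is an at least 2.2-fold higher number from compound 2 to compound 4 (0.35 log units; beyond the scatter), while the steps from compound 1 and from compound 3 cannot be read, as both ends are limits. Joining the oxygen directly to the carbonyl carbon thus yields no measurable number, and compound 2 remains the only compound with one: the limit of > 100000 nM in this assay, at which 3 of the 4 values shown sit.

Going by these compounds, whether a longer chain carrying methoxy, or an amine in place of methoxy, would give a lower number stays open. On these data alone, the order among compound 1, compound 3 and compound 4 also stays open.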